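A few compounds are considered here, and "the series" means these few. Any claim that something is new, unique, unknown or untested is made for them only; others in the source may bear on it.

The two measured compounds and their values:

compound 1 `CNCc1cn(S(=O)(=O)c2cccs2)c(-c2cccnc2F)c1F` — 98%
compound 2 `CNCc1cn(S(=O)(=O)c2ccc(OC)cn2)c(-c2cccnc2F)c1F` — 95%

In a functional assay on the whole organism (strain Jcl:Sprague-Dawley) for inhibition, with Rattus norvegicus as the target, with stated times of 3 min and 3 h, at a dose of 1 mg/kg by the intravenous route (on this read-out higher numbers stand for more inhibition at the one dose given (going by the name of the read-out) and lower numbers for less inhibition), compound 1 gives 98%. In this assay compound 2 gives 95%. Among the compounds with values here, these two values lie within the usual scatter of each other, so compound 2 cannot be told apart from compound 1 on these numbers; the only measured step, a number 3 percentage points lower from compound 1 to compound 2 (within the scatter), swapped the group on the sulfonyl sulfur and left the read-out essentially unchanged.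

Compound 3 `CNCc1cn(S(=O)(=O)c2ncccc2C)c(-c2cccnc2F)c1F` is not yet measured. It differs from compound 2 in one place: 3-methylpyridin-2-yl in place of 5-methoxypyridin-2-yl on a sulfonyl sulfur. This change again alters only the group on the sulfonyl sulfur, the same place touched in the step from compound 1 to compound 2. Within the data shown here, that one step is the only measured evidence bearing on it, and it stayed within the scatter, so no step beyond the scatter is expected here either; the expected shift is a number 2 percentage points lower from compound 2 to compound 3 (within the scatter). On this basis compound 3 is estimated to give 93% in this assay, with a range from 80% to 99%.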

Compound 3, a percentage reported as inhibition, in the whole organism at one dose (the size of the read-out at that dose, not a potency): 54%
Compound 3: the middle estimate sits 39 percentage points above what was measured, outside the stated range (below it).
By their numbers in this assay, from the lowest: compound 3; then compounds 2 and 1 (each within the scatter of the next).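

The group on the sulfonyl sulfur can matter a great deal, which the earlier swap gave no sign of. In this assay there is a number 41 percentage points lower from compound 2 to compound 3 (beyond the scatter) and also a number 44 percentage points lower from compound 1 to compound 3 (beyond the scatter) when 3-methylpyridin-2-yl is the group on the sulfonyl sulfur, and both of these large steps lie well beyond the scatter. Because 5-methoxypyridin-2-yl and 3-methylpyridin-2-yl are both six-membered aromatic rings with one hetero atom, the ring type alone does not decide the outcome: compound 2 and compound 3 share it and still end up far apart, so the substituent on that ring or its location must count.

The step from compound 2 to compound 3 changes the substituent and its location together, so an unsubstituted pyridin-2-yl, a 5-methylpyridin-2-yl or a 3-methoxypyridin-2-yl group would be needed to tell apart the effect of the methyl group, the loss of the methoxy group and the location on the ring. Nothing available here bears on what lies behind this large loss of inhibition.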